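Extending the cyclohexyl chain of a thiourea series

The source may hold more compounds than are shown below. What is called first, only, known or untested is meant among the compounds shown, and "the series" means these compounds.

Compound 1 `CC[C@H]1CC[C@H](c2ccc(NC(=S)Nc3cccc(C(F)(F)F)c3)cc2)CC1`: 10000 nM
Compound 2 `O=C(NC(=S)Nc1cccc(C(F)(F)F)c1)[C@H]1C[C@@H]2CC[C@H]1C2`: 20000 nM
Compound 3 `Fc1ccc(NC(=S)Nc2cccc(C(F)(F)F)c2)cc1Cl`: 20000 nM

Three thioureas sharing a trifluoromethyl-substituted aryl group have been examined in an ADME assay on Vero 76 cells (Chlorocebus sabaeus) for cytotoxicity, read by crystal violet staining, with a stated time of 96 h; on this read-out lower numbers stand for higher toxicity in this test and higher numbers for lower toxicity in this test. Compound 1 gives 10000 nM, compound 2 gives 20000 nM and compound 3 gives 20000 nM. Compound 1 holds the smallest of the three numbers, yet compound 2 and compound 3 both lie within the usual scatter of it, so the three compounds cannot be told apart on this read-out.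

The next compound, compound 4 `CCCC[C@H]1CC[C@H](c2ccc(NC(=S)Nc3cccc(C(F)(F)F)c3)cc2)CC1`, has not yet been measured in this assay. It is derived from compound 1 by one change: ethyl in place of hydrogen on a saturated chain carbon, two bonds along the chain from a saturated ring carbon. Among the measured compounds shown here, no step of this kind has been measured between the three compounds known so far, so there is nothing in the data to say how this assay responds to a longer chain here. With the three known values sitting so close together, the expectation is a small step, if any, from compound 1 to compound 4, most likely toward a somewhat lower number but not beyond the scatter, so that a 1.4-fold lower number from compound 1 to compound 4 (0.15 log units; within the scatter) is the expected step. On that basis compound 4 is estimated at 7000 nM, with a range from 3000 nM to 20000 nM.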

Compound 4, half-maximal cytotoxic concentration: 17000 nM
The estimate for compound 4 lay 2.4-fold (0.39 log units) below the measured number; the range from low to high includes it.
By their numbers in this assay, from the lowest: compounds 1, 4, 2 and 3 (each within the scatter of the next).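

In this assay, among the compounds shown here, the change from 4-ethylcyclohexyl to 4-butylcyclohexyl gives the first step that can be read at this position, with ethyl in place of hydrogen on a saturated chain carbon, two bonds along the chain from a saturated ring carbon: a 1.7-fold higher number from compound 1 to compound 4 (0.23 log units; within the scatter). For the compounds shown here, the three earlier compounds offered no such pair, so they could not show how this read-out responds to the length of this chain; this one step shows that the added ethyl does not separate compound 4 from compound 1 in this test. Nothing available bears on why the two compounds read alike, and the result rests on this single pair.

What the compounds shown leave open is whether the same holds for a longer chain, such as hexyl or octyl, at this position, or for a chain ending in a hydroxyl group, an amine or a carboxylic acid. They also leave open whether this ethyl change would read the same on a core other than that of compound 1.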